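The source may report more compounds than this note shows. Statements on the series, on what has been measured and on what is new or still open speak of the compounds shown alone.

Within the data shown here, in a physicochemical assay for solubility, read by HPLC, in phosphate buffer, measured as kinetic solubility, with a stated time of 24 h, at pH 7.4 (a lower number here means a less soluble compound, a higher number a more soluble compound), compound 1 `NC1CCc2nc(-c3ccncc3)nc(Nc3cccc(F)c3)c2C1` gives 126000 nM, the only actual number available for this small series. Compound 2 `COc1cccc(Nc2nc(-c3ccncc3)nc3c2CC(N)CC3)c1` is reported at > 250000 nM, which is a limit of the assay and not a number. Among the measured compounds shown here, the single measured step, an at least 1.9-fold higher number from compound 1 to compound 2 (0.29 log units; that floor lies within the scatter), is methoxy in place of fluoro on an aromatic carbon.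

Compound 3 `NC1CCc2nc(-c3cccnc3)nc(Nc3cccc(F)c3)c2C1` has the same atoms as compound 1, joined differently: pyridin-3-yl in place of pyridin-4-yl on an aromatic carbon. Here pyridin-3-yl stands in place of pyridin-4-yl on an aromatic carbon, between two ring nitrogen atoms. For the measured compounds named here, no measured step changes this group. The step of an at least 1.9-fold higher number from compound 1 to compound 2 (0.29 log units; that floor lies within the scatter) concerns a different group, so it offers no direction and no size for this change, and no shift beyond the scatter is expected in this assay.

The estimated step is a 1.1-fold lower number from compound 1 to compound 3 (0.02 log units; within the scatter), a change expected to stay within the scatter. On that basis, compound 3 is expected at 120000 nM, with an estimated range of 50000 nM to 240000 nM.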

Compound 3, solubility: > 250000 nM
Compound 3: only a limit was reported; the forecaster's own chance of this, stated with the estimate: 10%; middle value at least 2.0-fold (0.31 log units) away from the limit.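

In this assay compound 3 is reported at > 250000 nM, which is a limit of the assay and not a number. Among these compounds, this is the first measured change at the place between two ring nitrogen atoms, and pyridin-3-yl in place of pyridin-4-yl reads as an at least 1.9-fold higher number from compound 1 to compound 3 (0.29 log units; that floor lies within the scatter), so the earlier step on the aromatic ring of the (3-fluorophenyl)amino group is no longer the only one available. The floor of this new step lies within the scatter, so it neither establishes a real shift nor excludes a larger one, and its true size cannot be read, because the reading stops at a limit: the limit of > 250000 nM in this assay, at which 2 of the 3 values shown sit.

The compounds shown leave open how a plain phenyl ring or a pyridin-2-yl group would read at this same place, where only the two pyridine isomers appear so far. They also leave open how the amine on the shared core bears on these readings, for instance with an acetamide in its place.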